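Octylsulfonamide benzoic acids: swapping a biaryl arm for an ethyl link

This account rests on a few compounds, and the source may have more. Where it says the series, first, only, none or still open, it means among the compounds named here.

Three measured compounds share an octylsulfonamido benzoic acid core carrying one further group. Compound 1 `CCCCCCCCS(=O)(=O)Nc1cc(-c2cccc(F)c2)ccc1C(=O)O` gives 32600 nM in an assay on mitochondria (strain BALB/c) for inhibition of glycerol-3-phosphate acyltransferase 1, mitochondrial (Mus musculus), read by scintillation counting, with a stated time of 10 min; on this read-out lower numbers stand for stronger inhibition and higher numbers for weaker inhibition. Compound 2 `CCCCCCCCS(=O)(=O)Nc1ccc(-c2ccc(CCCC)cc2)cc1C(=O)O` gives 9000 nM, the lowest of the three numbers, with compound 1 and compound 3 both giving higher numbers, each beyond the scatter. Compound 3 `CCCCCCCCS(=O)(=O)Nc1cc(CCc2ccc(OC)cc2)ccc1C(=O)O` gives 43000 nM.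

Compound 4 `CCCCCCCCS(=O)(=O)Nc1ccc(CCc2ccc(OC)cc2)cc1C(=O)O` is not yet measured. Its change from compound 2: 2-(4-methoxyphenyl)ethyl in place of 4-butylphenyl on an aromatic carbon

Among the compounds with values here, the only measured step that touches the entering group is a 1.3-fold higher number from compound 1 to compound 3 (0.12 log units; within the scatter), where the same 2-(4-methoxyphenyl)ethyl replaced an aromatic group at another position on the core and the number barely moved. Within the data shown here, no step exchanges 4-butylphenyl for anything, and compound 2 and compound 1 differ in both group and place, so their gap cannot be assigned. The expectation for this assay is therefore a small shift, at most a modest weakening, within or near the scatter.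

Compound 4 is estimated at 15000 nM, with a range from 6000 nM to 45000 nM; the expected step is a 1.7-fold higher number from compound 2 to compound 4 (0.22 log units; within the scatter).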

Compound 4, half-maximal inhibitory concentration: 26300 nM
The estimate for compound 4 lay 1.8-fold (0.24 log units) below the measured number; the range from low to high includes it.
By their numbers in this assay, from the lowest: compound 2; then compounds 4, 1 and 3 (each within the scatter of the next).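

In this assay, within the data shown here, putting 2-(4-methoxyphenyl)ethyl in place of 4-butylphenyl on the aromatic carbon meta to the carboxy group gives a 2.9-fold higher number from compound 2 to compound 4 (0.47 log units; beyond the scatter), the only step read at this position and one that lies beyond the scatter. The two groups match in heavy-atom count and each holds one six-membered aromatic ring, yet they differ in the oxygen and hydrogen-bond acceptor that enter, so this position registers an exchange that leaves both counts unchanged. No available evidence bears on what lies behind the shift.

Among these compounds, the single step changes the link, the chain and the oxygen together, so their shares remain unassigned. A 4-methoxyphenyl group or a 2-(4-butylphenyl)ethyl group at this position would separate the aryl link from the substituent on the ring.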